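Compound 2 gains a 2-cyanophenyl group

The source may hold more compounds than are shown below. What is called first, only, known or untested is meant among the compounds shown, and "the series" means these compounds.

In an ADME assay on MT4 cells (Homo sapiens) for cytotoxicity, read by MTT assay, with a stated time of 5 days (a lower number here means that less compound is tolerated, a higher number that more compound is tolerated), compound 1 (`Cc1cc(C)cc(S(=O)(=O)c2c(C(=O)NC3CNC3)[nH]c3ccc(Cl)cc23)c1`) gives 37300 nM as its reading. Compound 2 (`Cc1cc(C)cc(S(=O)(=O)c2c(C(=O)N[C@@H]3CCN(Cc4n[nH]c(=O)n4C)C3)[nH]c3ccc(Cl)cc23)c1`) gives 22400 nM in the same test, which places it within the scatter of compound 1. Compound 3 (`Cc1cc(C)cc(S(=O)(=O)c2c(C(=O)N[C@@H]3CCN(Cc4ccccc4C#N)C3)[nH]c3ccc(Cl)cc23)c1`) differs from compound 2 by one exchange on a saturated chain carbon bound to an amine nitrogen in a ring (a group of 8 heavy atoms (7 carbon, 1 nitrogen; one six-membered aromatic ring of carbon only) in place of a group of 7 heavy atoms (3 carbon, 3 nitrogen, 1 oxygen; one five-membered aromatic ring with 3 hetero atoms), on a saturated chain carbon bound to an amine nitrogen in a ring). There, 2-cyanophenyl enters, so one six-membered aromatic ring of carbon only stands in place of one five-membered aromatic ring with 3 hetero atoms. Among the measured compounds shown here, no two measured compounds differ in one place, so nothing measured shows this exchange directly. In this assay the expected step is small and leans toward a lower number: a 1.6-fold lower number from compound 2 to compound 3 (0.20 log units; within the scatter) is estimated, not clearly beyond the scatter. Compound 3 is estimated at 14000 nM within an expected range from 5000 nM to 38000 nM for now.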

Compound 3, half-maximal cytotoxic concentration: >= 186000 nM
Compound 3 gave a limit, no number; the forecaster's own chance of this, stated with the estimate: 15%; at least 13-fold (1.12 log units) between middle value and limit.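

In this assay, replacing the five-membered aromatic ring with 3 hetero atoms with 2-cyanophenyl, on a saturated chain carbon bound to an amine nitrogen in a ring, gives an at least 8.3-fold higher number from compound 2 to compound 3 (0.91 log units; beyond the scatter). Among the compounds shown here, compound 3 reads as a limit of the assay, not as a number: the limit of >= 186000 nM in this assay, at which 1 of the 3 values shown sits. The earlier compounds offered no pair differing in one place, so this is the first sign that the group at this position can move the reading beyond the scatter.

The compounds shown leave open whether the step belongs to the nitrile or to the six-membered aromatic ring of carbon only, and a plain phenyl group at the same place would separate the two. They also do not show whether an amine or a carboxylic acid on that ring would give a similar reading.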